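This account rests on a few compounds, and the source may have more. Where it says the series, first, only, none or still open, it means among the compounds named here.

Measured in a functional assay on MDA-MB-468 cells (Homo sapiens) for antiproliferative activity; a higher number here means a weaker inhibitor, a lower number a stronger inhibitor:
- compound 1 `CC(=O)Nc1ccc(-c2nc3ccccc3s2)cc1C`: > 10000 nM, a limit
- compound 2 `CC(=O)Nc1ccc(-c2nc3ccccc3s2)cc1Cl`: > 100 nM, a limit

Compound 2 has no exact value and is known only by its limit of > 100 nM. For the measured compounds named here, the sole measured step is a step that the two limits leave unreadable from compound 1 to compound 2, so it offers no size or direction to carry forward.

Compound 3 `CC(=O)Nc1ccc(-c2nc3ccccc3s2)cc1I` carries iodo in place of chloro on an aromatic carbon, ortho to an acetamido group: iodo in place of chloro on an aromatic carbon.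

With no readable halogen step, no particular size or direction of change can be expected in this assay. The expectation is anchored on the limit of compound 2 at > 100 nM, and it stays wide. The expected step is a step that the limit leaves unreadable from compound 2 to compound 3, and it carries little weight. For compound 3 the estimated value is 300 nM, with an expected range of 20 nM to 5000 nM.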

Compound 3, half-maximal inhibitory concentration: > 100 nM
Compound 3 ended at the assay's limit; the forecaster's own chance of this, stated with the estimate: 40%; the middle value lies beyond the limit too.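

In this assay, for the compounds shown here, compound 1, compound 2 and compound 3 are known only by limits, and no step among them can be read. Left open is how methyl, chloro and iodo on this aromatic carbon rank against one another.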